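The compounds below may be only part of what the source reports. "The series", "measured", "known", "first", "only" and "open" are said of these compounds alone.

Compound 3 `Cc1noc(C)c1-c1cnc(N)c(Oc2ccc(C(=O)Nc3ccc(Cl)cc3)cc2)n1` gives the lowest number of the three measured compounds in a functional assay on U-87MG ATCC cells for inhibition, with U-87 MG (Homo sapiens) as the target, read by MTT assay, with a stated time of 72 h (on this read-out lower numbers stand for stronger inhibition and higher numbers for weaker inhibition), namely 15500 nM. Compound 1 `Cc1noc(C)c1-c1cnc(N)c(Oc2ccc(C(=O)NC3CCCC3)cc2)n1` gives 57600 nM in this assay, and compound 2 `Cc1noc(C)c1-c1cnc(N)c(Oc2ccc(C(=O)Nc3ccccc3Cl)cc2)n1` gives 60500 nM. The measured steps are a 3.7-fold lower number from compound 1 to compound 3 (0.57 log units; beyond the scatter), a 3.9-fold lower number from compound 2 to compound 3 (0.59 log units; beyond the scatter) and a 1.1-fold higher number from compound 1 to compound 2 (0.02 log units; within the scatter); all three concern only the group on the amide nitrogen.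

Compound 4 `Cn1cc(-c2cnc(N)c(Oc3ccc(C(=O)Nc4ccc(Cl)cc4)cc3)n2)cn1` differs from compound 3 in a different place: 1-methyl-1H-pyrazol-4-yl in place of 3,5-dimethyl-1,2-oxazol-4-yl on an aromatic carbon. Within the data shown here, no measured step touches this position, so the series offers no direct guide to the direction or size of this change. With the amide part held as in compound 3, and with both the leaving and the entering groups being five-membered aromatic rings with two hetero atoms and no donors, the working assumption is that compound 4 is expected to stay close to compound 3, with an expected step of no change at the digits printed from compound 3 to compound 4 (within the scatter) not beyond the scatter. The estimate for compound 4 in this assay is 15500 nM, expected within the range 5000 nM to 50000 nM.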

Compound 4, half-maximal inhibitory concentration: 35800 nM
Compound 4: the middle estimate sits 2.3-fold (0.36 log units) below what was measured; low and high end bracket the measured number.
By their numbers in this assay, from the lowest: compound 3; then compounds 4, 1 and 2 (each within the scatter of the next).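

In this assay, the aromatic carbon para to an amino group proves sensitive to the ring placed on it: 1-methyl-1H-pyrazol-4-yl in place of 3,5-dimethyl-1,2-oxazol-4-yl gives a 2.3-fold higher number from compound 3 to compound 4 (0.36 log units; beyond the scatter), so the number depends on more than the group on the amide nitrogen. This step appears even though both groups are five-membered aromatic rings with 2 hetero atoms, 0 hydrogen-bond donors and 2 hydrogen-bond acceptors, so these shared counts do not fix the number at this position. No available evidence bears on the origin of this step.

Among these compounds, the ring change is seen only with the 4-chlorophenyl group on the amide nitrogen, so whether it carries over to the cyclopentyl of compound 1 or the 2-chlorophenyl of compound 2 remains open. Also open, from the compounds shown here alone, is how an unsubstituted phenyl ring or a morpholine at this position would compare with these two five-membered rings.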